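Amine tail variation on the shared core

The source may report more compounds than this note shows. Statements on the series, on what has been measured and on what is new or still open speak of the compounds shown alone.

Compound 1 `COc1cc2c(Nc3nc4ccc(C(=O)Nc5c(C)cc(C)cc5C)cc4s3)ncnc2cc1OCCCN1CCC(C)CC1` carries a 4-methylpiperidin-1-yl group three bonds along the chain from an oxygen on an aromatic ring. Among the compounds with values here, in a functional assay on U-937 cells (Homo sapiens) for cytotoxicity, read by WST assay, with a stated time of 72 h (on this read-out higher numbers stand for weaker inhibition and lower numbers for stronger inhibition), compound 1 gives 5600 nM, the lowest of the two numbers so far. Compound 2 `COc1cc2c(Nc3nc4ccc(C(=O)Nc5c(C)cccc5C)cc4s3)ncnc2cc1OCCCN1CCCC1` gives 18900 nM in this assay, a higher number than compound 1 by more than the scatter. Within the data shown here, no step between measured compounds that differ in one place is available, so compound 2 serves only as a second point.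

Compound 3 `CCN(CC)CCCOc1cc2ncnc(Nc3nc4ccc(C(=O)Nc5c(C)cc(C)cc5C)cc4s3)c2cc1OC` differs from compound 1 by diethylamino in place of 4-methylpiperidin-1-yl on a saturated chain carbon, three bonds along the chain from an oxygen on an aromatic ring. Among the measured compounds shown here, with no single-point step on record, the step of a 1.3-fold higher number from compound 1 to compound 3 (0.10 log units; within the scatter) is expected to stay near or within the scatter, if anything toward a slightly higher number. Compound 3 is estimated at 7000 nM in this assay, with an expected range from 3000 nM to 18000 nM.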

Compound 3, half-maximal inhibitory concentration: 4300 nM
Compound 3: middle estimate off by 1.6-fold (0.21 log units), on the high side, within the range that was stated.
By their numbers in this assay, from the lowest: compounds 3 and 1 (each within the scatter of the next); then compound 2.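

In this assay, within the data shown here, diethylamino in place of 4-methylpiperidin-1-yl on a saturated chain carbon, three bonds along the chain from an oxygen on an aromatic ring, gives a 1.3-fold lower number from compound 1 to compound 3 (0.11 log units; within the scatter) and is the first step at this position that can be read. A ring in the amine tail is therefore not needed to keep the value in this range, as the open diethylamino group and the 4-methylpiperidin-1-yl group read alike on the shared core. Nothing on hand bears on why the two tails read alike.

Compound 2 differs from compound 1 in more than one place, so its higher number cannot be assigned to its pyrrolidine ring alone. Still open, on these data alone, is how a morpholine ring, a primary amine or a shorter chain would read at this position.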